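From cyano to bromo: what compound 4 may show

This account rests on a few compounds, and the source may have more. Where it says the series, first, only, none or still open, it means among the compounds named here.

compound 1 `C=CCc1cc(O)c(O)c(CN2CCC(CCO)CC2)c1`: 39.4%
compound 2 `C=CCc1ccc(OCc2cn(-c3ccc(C#N)cc3)nn2)c(O)c1`: 20.8%
compound 3 `C=CCc1cc(O)c(O)c(CN2CCC(Cc3ccccc3)CC2)c1`: 90.6%

All three values come from a functional assay on HL-60 cells (Homo sapiens) for inhibition, read by MTT assay, with a stated time of 72 h, tested at 30 uM; on this read-out lower numbers stand for less inhibition of growth and higher numbers for more inhibition of growth at the one concentration tested. Among them, compound 2 stands lowest at 20.8%, and the gaps to the other two lie beyond the usual scatter. Compound 1 is its nearest neighbour and compound 3 its furthest.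

The next compound is compound 4 `C=CCc1ccc(OCc2cn(-c3ccc(Br)cc3)nn2)c(O)c1`, which keeps the rest of compound 2 and changes one group: bromo in place of cyano on an aromatic carbon. In words, this is bromo in place of cyano on an aromatic carbon, taking 4-cyanophenyl to 4-bromophenyl.

For the measured compounds named here, only one measured step exists, a number 51.2 percentage points higher from compound 1 to compound 3 (beyond the scatter). It is large, but it concerns phenyl in place of hydroxymethyl on a saturated chain carbon, on a different core, so it gives no size for this change. Going by the values given here, it shows only that one exchange can move this assay a long way. Among the compounds with values here, no measured pair exchanges cyano for bromo. A small rise, not clearly beyond the scatter, is therefore expected, since compound 2 at 20.8% leaves more room upward than downward. The expected change is a number 7.2 percentage points higher from compound 2 to compound 4 (within the scatter). For compound 4 the estimated value is 28%, with an expected range from 10% to 50%.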

Compound 4, percent growth inhibition at one concentration: 22.1%
For compound 4 the middle estimate is 5.9 percentage points above the measured one, within the range that was stated.
By their numbers in this assay, from the lowest: compounds 2 and 4 (each within the scatter of the next); then compound 1; then compound 3.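

In this assay, the exchange of the nitrile for bromo on the aromatic carbon gives a number 1.3 percentage points higher from compound 2 to compound 4 (within the scatter), so this change at the position para to a large group leaves the growth inhibition at the one tested concentration within the usual scatter. Cyano, with its two heavy atoms, triple bond and hydrogen-bond acceptor, and bromo, with one heavy atom and no hydrogen-bond acceptor, therefore cannot be told apart here, even though a number 51.2 percentage points higher from compound 1 to compound 3 (beyond the scatter), a step on another core and at another place, had shown that this read-out can move a long way. No measurement is at hand that would account for this lack of change.

What the compounds shown leave open is whether any group on this aromatic carbon can move the read-out, for instance an amine, a carboxylic acid or a longer chain such as butyl in place of bromo. They also leave open whether the exchange of cyano for bromo would stay as small on the core of compound 3 , where the number is far higher.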